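A Fluoro Substitution Carried Across to a Second Core

A few compounds are considered here, and "the series" means these few. Any claim that something is new, unique, unknown or untested is made for them only; others in the source may bear on it.

Compound 1, `COc1cccc(-c2cc(C(=O)Nc3ccc(Oc4ccnc5cc(OCCCN6CCCCC6)c(OC)cc45)c(F)c3)c3ccccc3n2)c1`: 1740 nM
Compound 2, `COc1cc2c(Oc3ccc(NC(=O)c4cc(-c5cccc(Cl)c5)nc5ccccc45)cc3F)ccnc2cc1OCCCN1CCC(C)CC1`: 100 nM
Compound 3, `COc1cccc(-c2cc(C(=O)Nc3ccc(Oc4ccnc5cc(OCCCN6CCCCC6)c(OC)cc45)c(F)c3)c3cc(F)ccc3n2)c1`: 2500 nM

In a functional assay on HT-29 cells (Homo sapiens) for cytotoxicity, read by MTT assay, with a stated time of 72 h (on this read-out lower numbers stand for stronger inhibition and higher numbers for weaker inhibition), compound 2 gives 100 nM, the lowest of the three numbers. Compound 1 gives 1740 nM and compound 3 gives 2500 nM, and both of these gaps to compound 2 are beyond the scatter. How the core of compound 2 differs from the core of compound 1 is not broken down here.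

Compound 3 differs from compound 1 in one place only: fluoro in place of hydrogen on an aromatic carbon. That change produced the step of a 1.4-fold higher number from compound 1 to compound 3 (0.16 log units; within the scatter), which lies within the scatter, so the two values cannot be ordered.

Compound 4, `COc1cc2c(Oc3ccc(NC(=O)c4cc(-c5cccc(Cl)c5)nc5ccc(F)cc45)cc3F)ccnc2cc1OCCCN1CCC(C)CC1`, has not yet been measured. Going by the values given here, it differs from compound 2 by fluoro in place of hydrogen on an aromatic carbon, which is the same change at the same kind of place as the one separating compound 3 from compound 1. Among the compounds shown, this change occurs twice in all, and only one of the two instances has been measured.

With nothing else to go on, the expectation rests on the step of a 1.4-fold higher number from compound 1 to compound 3 (0.16 log units; within the scatter) seen on the other core. For compound 4 the step from compound 2 is estimated to be a 1.4-fold higher number from compound 2 to compound 4 (0.15 log units; within the scatter), because that is what a 1.4-fold higher number from compound 1 to compound 3 (0.16 log units; within the scatter) showed. Compound 4 is therefore expected to give about 140 nM in this assay, with a likely range from 60 nM to 350 nM, the range being wide since a single earlier instance is a thin basis.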

Compound 4, half-maximal inhibitory concentration: 92 nM
Estimate against measurement, compound 4: 1.5-fold (0.18 log units) above; the range from low to high includes it.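

On the core of compound 2, fluoro in place of hydrogen on an aromatic carbon gave a 1.1-fold lower number from compound 2 to compound 4 (0.04 log units; within the scatter) in this assay, so the two values of this pair cannot be ordered. Set beside the same change on the core of compound 1, the new step gives no sign that the result depends on the core, and the two steps cannot be told apart: the same change on two cores in this assay, a 1.4-fold higher number (0.16 log units; within the scatter) from compound 1 to compound 3 and a 1.1-fold lower number (0.04 log units; within the scatter) from compound 2 to compound 4, 1.6-fold (0.19 log units) apart, within the scatter of two such steps This shows that, in these two pairs, the fluoro change carried across without moving the number beyond the scatter, but it does not show a true small effect of the change on either core, and the opposite signs of the two steps are no reversal, while two pairs in a single cell assay cannot establish a rule for the whole series.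

The compounds shown leave open whether another group on that same aromatic carbon, such as a nitrile or an amine, would give a step beyond the scatter on either core. They also leave open which of the several places separating compound 1 from compound 2 accounts for the large gap between their values, since no single-place step connects the two.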